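This account rests on a few compounds, and the source may have more. Where it says the series, first, only, none or still open, it means among the compounds named here.

Working notes on the series. Compound 1 `C[C@@H]1CN(c2sc(C(F)(F)F)nc2-c2nc3ccccc3[nH]2)CCN1C(=O)Cn1cccn1` carries a pyrazolyl group on the saturated chain carbon bound to the carbonyl carbon; in a functional assay on Venous blood for antagonist activity at C-X-C chemokine receptor type 3 (Homo sapiens), read by flow cytometry, with a stated time of 30 min, in the presence of a further agent that is not named here (on this read-out higher numbers stand for weaker inhibition and lower numbers for stronger inhibition), compound 1 gives 191 nM. Compound 3 `Cc1nc(C)n(CC(=O)N2CCN(c3sc(C(F)(F)F)nc3-c3nc4ccccc4[nH]3)C[C@H]2C)n1` carries 3,5-dimethyl-1H-1,2,4-triazol-1-yl at that place instead, and compound 3 gives 237 nM; the step of a 1.2-fold higher number from compound 1 to compound 3 (0.09 log units; within the scatter) stays within the scatter. Among the measured compounds shown here, compound 2 `C[C@@H]1CN(c2sc(C(F)(F)F)nc2-c2nc3cc(Cl)ccc3[nH]2)CCN1C(=O)Cn1cnc2cccnc21` differs from both in two places and gives 38.5 nM, so it supplies no single-change step. On the numbers shown, compound 3 stands at the highest value, with compound 1 within the scatter of it and compound 2 beyond the scatter below it.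

Compound 4 `C[C@@H]1CN(c2sc(C(F)(F)F)nc2-c2nc3ccccc3[nH]2)CCN1C(=O)Cn1cnc2cccnc21` is the next step from compound 3: a group of 9 heavy atoms (6 carbon, 3 nitrogen; one five-membered aromatic ring with 2 hetero atoms, one six-membered aromatic ring with 1 hetero atom) in place of a group of 7 heavy atoms (4 carbon, 3 nitrogen; one five-membered aromatic ring with 3 hetero atoms), on a saturated chain carbon bound to a carbonyl carbon. For the measured compounds named here, no measured step isolates this exchange. Going by the values given here, the only step at the same place, from compound 1 to compound 3, lies within the scatter. Compound 2 carries the entering group together with a chloro substituent, so its value of 38.5 nM cannot be credited to the entering group alone. For compound 4 in this assay the expected step is a 2.4-fold lower number from compound 3 to compound 4 (0.37 log units; beyond the scatter), toward lower numbers but uncertain in size. Compound 4 is estimated at 100 nM, with a range from 40 nM to 250 nM.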

Compound 4, half-maximal inhibitory concentration in the C-X-C chemokine receptor type 3 assay: 70 nM
Beside the measured number, compound 4's estimate is 1.4-fold (0.15 log units) above it, within the range that was stated.
By their numbers in the C-X-C chemokine receptor type 3 assay, from the lowest: compounds 2 and 4 (each within the scatter of the next); then compounds 1 and 3 (each within the scatter of the next).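

In the C-X-C chemokine receptor type 3 assay, the group on the saturated chain carbon bound to a carbonyl carbon now changes the number beyond the scatter, with a 3.4-fold lower number from compound 3 to compound 4 (0.53 log units; beyond the scatter) and a 2.7-fold lower number from compound 1 to compound 4 (0.44 log units; beyond the scatter), whereas the earlier step at this place stayed within it. Removing the chloro substituent gives a 1.8-fold higher number from compound 2 to compound 4 (0.26 log units; within the scatter), which lies within the scatter, so the low number of compound 2 need not be credited to the chloro substituent. In a physicochemical assay for solubility, in simulated intestinal fluid (a higher number here means a more soluble compound, a lower number a less soluble compound), compound 3 gives > 850 ug/mL, which is a limit of the assay and not a number. In the physicochemical assay compound 4 gives 214 ug/mL. In the physicochemical assay the same exchange gives an at least 3.9-fold lower number from compound 3 to compound 4 (0.59 log units; beyond the scatter), a bound rather than an exact size, set by the limit of compound 3: the limit of > 850 ug/mL in the physicochemical assay, at which 1 of the 2 values shown sits.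

Open, as far as these compounds go, is whether an amine or a carboxylic acid at this place would keep the lower number in the C-X-C chemokine receptor type 3 assay without a lower number in the physicochemical assay. Equally open, from the compounds shown here alone, is how a longer chain at this place would read in either assay.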